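The source may hold more compounds than are shown below. What is called first, only, known or untested is meant among the compounds shown, and "the series" means these compounds.

Compound 1 `Oc1ccc(/C=N/c2ccc(OCc3ccccc3)cc2)c(O)c1`: in a functional assay, with a stated time of 30 min (a higher number here means a weaker inhibitor, a lower number a stronger inhibitor), compound 1 gives only a limit, > 200000 nM.
Compound 2 `Oc1cccc(/C=N/c2ccc(OCc3ccccc3)cc2)c1O`: in this assay compound 2 gives 13300 nM.

Compound 2 holds the only true number shown; the other value is a limit, (the limit of > 200000 nM in this assay, at which 1 of the 2 values shown sits). Among the measured compounds shown here, the single step measured so far, from compound 1 to compound 2, was an at least 15-fold lower number from compound 1 to compound 2 (1.17 log units; beyond the scatter). That step moved a hydroxy group on the ring bonded to the carbon with a double bond to nitrogen, without changing how many hydroxy groups the ring carries.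

Compound 3 `Oc1ccc(/C=N/c2ccc(OCc3ccccc3)cc2)c(O)c1O` differs from compound 2 by hydroxy in place of hydrogen on an aromatic carbon. The measured step bears on this only loosely, since it concerns the position of hydroxy groups rather than their number. For the measured compounds named here, no step of the same kind has been measured, so a change within the scatter is expected, with the step from compound 2 to compound 3 estimated as a 1.3-fold lower number from compound 2 to compound 3 (0.12 log units; within the scatter). In this assay compound 3 is therefore expected to give about 10000 nM, estimated between 3000 nM and 40000 nM.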

Compound 3, half-maximal inhibitory concentration: 43400 nM
Estimate against measurement, compound 3: 4.3-fold (0.64 log units) below; measured number outside the range, above it.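

Adding a hydroxy group is not a neutral change on this ring. Placed para to a large group, ortho to one hydroxy group and meta to another, it gives in this assay a 3.3-fold higher number from compound 2 to compound 3 (0.51 log units; beyond the scatter), while adding a hydroxy group on a different aromatic carbon of the ring gives an at least 4.6-fold lower number from compound 1 to compound 3 (0.66 log units; beyond the scatter), so the same kind of change can go in either direction depending on where the new group sits relative to those already present. Compound 1 gives only a limit, so the second step is a bound and not a measured size: the limit of > 200000 nM in this assay, at which 1 of the 3 values shown sits.

The compounds shown leave open whether a methoxy group or an amine at the same carbon would behave like hydroxy. They also leave open how the ring behaves with a single hydroxy group.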